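The compounds below may be only part of what the source reports. "The series", "measured", "known", "first", "only" and "open" are said of these compounds alone.

Measured set in a functional assay on CHO cells for agonist activity at Free fatty acid receptor 1 (Homo sapiens); a lower number here means that less compound is needed, a higher number that more compound is needed for the effect: compound 1 `O=C(O)c1ccc(NCc2cccc(Oc3ccccc3)c2)cc1`; compound 2 `Cc1nc(-c2ccc(C(F)(F)F)cc2)sc1CNc1ccc(/C=C/C(=O)O)cc1`; compound 3 `O=C(O)CSc1ccc(NCc2cccc(Oc3ccccc3)c2)cc1`.

In this assay compound 2 gives 36.3 nM. In this assay compound 3 gives 324 nM. For compound 1 this assay reports only a limit, < 10000 nM. Compound 2 therefore stands lowest of the two numbers in the series, with compound 3 the nearest at a higher value, a gap beyond the scatter. For the measured compounds named here, the single step between measured compounds, a step that the limit leaves unreadable from compound 1 to compound 3, cannot be read because of the limit of < 10000 nM in this assay, at which 1 of the 3 values shown sits, and it does not touch the part of the molecule changed here in any case.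

Compound 4 `Cc1nc(-c2ccc(C(F)(F)F)cc2)sc1CNc1ccc([C@H]2C[C@@H]2C(=O)NC2CCNC2)cc1` differs from compound 2 in one place: 2-((pyrrolidin-3-yl)carbamoyl)cyclopropyl in place of 2-carboxyethenyl on an aromatic carbon. Going by the values given here, no measured step covers this change; no other compound exchanges the 2-carboxyethenyl for a group of this kind, so the expectation rests on the size of the change alone. A step toward a higher number is expected, an 83-fold higher number from compound 2 to compound 4 (1.92 log units; beyond the scatter). Compound 4 is estimated at 3000 nM, with a range from 400 nM to 20000 nM.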

Compound 4, half-maximal effective concentration: 204 nM
Beside the measured number, compound 4's estimate is 15-fold (1.17 log units) above it; the whole stated range lies above it.
By their numbers in this assay, from the lowest: compound 2; then compounds 4 and 3 (each within the scatter of the next).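

In this assay, replacing 2-carboxyethenyl with 2-((pyrrolidin-3-yl)carbamoyl)cyclopropyl gives a 5.6-fold higher number from compound 2 to compound 4 (0.75 log units; beyond the scatter), a modest step for a much larger group. Compound 1, compound 2 and compound 3 all carry a carboxylic acid, whereas compound 4 has none and still gives 204 nM, so on this core a carboxylic acid at this position is not required for activity in the nanomolar range. Nothing measured here accounts for the size of this step.

As far as these compounds go, the step combines the new three-membered ring, the amide and the pyrrolidine, and its share for each remains open. From the compounds shown here alone, a 2-carboxycyclopropyl group or a simple primary amide on the cyclopropyl at this position would help to separate them, and the opposite configuration at the two stereocentres also remains open.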